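The source may report more compounds than this note shows. Statements on the series, on what has been measured and on what is new or still open speak of the compounds shown alone.

In a functional assay on BXPC-3 cells (Homo sapiens) for inhibition, read by MTT assay, with a stated time of 7 days (a lower number here means a stronger inhibitor, a higher number a weaker inhibitor), compound 3 `O=C([C@@H]1CCCN(S(=O)(=O)c2ccc(S(=O)(=O)C3CCC3)cc2)C1)N1CCC(F)(F)CC1` gives 78 nM, the lowest number of the three measured compounds and clearly beyond the scatter of the other two. Compound 1 `CCN(CC)S(=O)(=O)c1ccc(S(=O)(=O)N2CCC[C@@H](C(=O)N[C@H]3CC[C@H](OC)CC3)C2)cc1` gives 2000 nM, and compound 2 `CCN(CC)S(=O)(=O)c1ccc(S(=O)(=O)N2CCC[C@@H](C(=O)N3CCC(O)CC3)C2)cc1` gives 4710 nM. Compound 4 `CN(C)S(=O)(=O)c1ccc(S(=O)(=O)N2CCC[C@@H](C(=O)N3CCC(F)(F)CC3)C2)cc1` keeps the difluoropiperidine amide of compound 3 and changes the other end of the molecule, with dimethylamino in place of cyclobutyl on a sulfonyl sulfur.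

Among the measured compounds shown here, no measured step makes this change. For the measured compounds named here, the only step available, a 2.4-fold higher number from compound 1 to compound 2 (0.37 log units; beyond the scatter), is modest, but it lies at the carbonyl carbon and so bears on this change only as a general guide to size. Compound 1 and compound 2 also carry a nitrogen-bearing group on the corresponding sulfonyl sulfur, and both show far higher numbers than compound 3. Yet they differ from compound 3 at the carbonyl carbon as well, so their gap cannot be assigned to the sulfonyl substituent alone. A modest move toward a higher number therefore seems more likely than a large one, and the expected step is a 2.2-fold higher number from compound 3 to compound 4 (0.34 log units; beyond the scatter). For compound 4 the estimated value is 170 nM, with an expected range from 45 nM to 650 nM.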

Compound 4, half-maximal inhibitory concentration: 560 nM
Compound 4: the middle estimate sits 3.3-fold (0.52 log units) below what was measured, within the range that was stated.
By their numbers in this assay, from the lowest: compound 3; then compound 4; then compound 1; then compound 2.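

In this assay, the sulfonyl sulfur whose other neighbour is an aromatic carbon proves to be a place that matters on its own: with the difluoropiperidine amide held constant, putting dimethylamino in place of cyclobutyl gives a 7.2-fold higher number from compound 3 to compound 4 (0.86 log units; beyond the scatter). Among the compounds shown here, the only earlier step, a 2.4-fold higher number from compound 1 to compound 2 (0.37 log units; beyond the scatter), lay on a carbonyl carbon, so this is the first reading of a change at the sulfonyl sulfur that is free of any change at the other end of the molecule. The change removes a four-membered carbon ring and brings in a nitrogen in one move, and no measurement shown accounts for the step.

The compounds shown therefore leave open whether the ring or the nitrogen goes with the higher number, a question that azetidin-1-yl, which holds both a four-membered ring and a nitrogen, or isopropyl, which holds neither, on the same sulfur could address. They also leave open whether cyclopentyl or cyclopropyl in place of cyclobutyl on that sulfur would keep the number of compound 3 or move it.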